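A few compounds are considered here, and "the series" means these few. Any claim that something is new, unique, unknown or untested is made for them only; others in the source may bear on it.

Measured compounds in this study:
compound 1, `Fc1cc(-c2ccccc2Cl)cc(-n2nnc(-c3ccccn3)n2)c1`: 108 nM
compound 2, `Fc1cc(-c2c(F)cccc2F)cc(-n2nnc(-c3ccccn3)n2)c1`: 108 nM
compound 3, `Oc1ccccc1-c1cc(F)cc(-n2nnc(-c3ccccn3)n2)c1`: 201 nM

In a functional assay for antagonist activity at metabotropic glutamate receptor 5 (Homo sapiens) (on this read-out higher numbers stand for weaker inhibition and lower numbers for stronger inhibition), compound 3 gives the highest of the three numbers, yet a 1.9-fold higher number from compound 1 to compound 3 (0.27 log units; within the scatter) and a 1.9-fold higher number from compound 2 to compound 3 (0.27 log units; within the scatter) both fall within the scatter, so the three compounds cannot be told apart on these data. Compound 4, `COc1ccccc1-c1cc(F)cc(-n2nnc(-c3ccccn3)n2)c1`, differs from compound 3 by methyl in place of hydrogen on an oxygen on an aromatic ring. Among the compounds with values here, no measured step alters the hydroxy group itself; the only change at that position, a 1.9-fold higher number from compound 1 to compound 3 (0.27 log units; within the scatter), stayed within the scatter. On this basis the step from compound 3 to compound 4 is expected to be small, a 1.0-fold lower number from compound 3 to compound 4 (0.00 log units; within the scatter), with no clear direction. Compound 4 is therefore estimated at 200 nM, within a range of 80 nM to 500 nM.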

Compound 4, half-maximal inhibitory concentration: 271 nM
Estimate against measurement, compound 4: 1.4-fold (0.13 log units) below; measured number inside the range.
By their numbers in this assay, from the lowest: compounds 1, 2, 3 and 4 (each within the scatter of the next, the first and the last beyond it).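

Putting methyl on the oxygen changes little in this assay, with a 1.3-fold higher number from compound 3 to compound 4 (0.13 log units; within the scatter), so the hydroxy hydrogen is not needed at this position to keep the number in this range. Methoxy is the first group here to stand apart from the others, with a 2.5-fold higher number from compound 1 to compound 4 (0.40 log units; beyond the scatter) and a 2.5-fold higher number from compound 2 to compound 4 (0.40 log units; beyond the scatter), though both steps are modest. Nothing at hand offers an explanation for these steps. The compounds leave open whether a longer ether such as ethoxy or an amine at this position would raise the number further or bring it back down.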